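The source may report more compounds than this note shows. Statements on the series, on what has been measured and on what is new or still open speak of the compounds shown alone.

The measured compounds and their activities:

- compound 1, `NC(=O)C[C@H](NC(=O)CN(c1nc(Cl)nc2[nH]cnc12)C1CC1)C(=O)O`: 17%
- compound 2, `C[C@@H](O)[C@H](NC(=O)CN(c1ncnc2c1ncn2C1CCCCO1)C1CC1)C(=O)OCc1ccccc1`: 10.9%
- compound 3, `O=C(CN(c1ncnc2c1ncn2C1CCCCO1)C1CC1)N[C@@H](CC(=O)OCc1ccccc1)C(=O)OCc1ccccc1`: 7.82%

In a functional assay on the whole organism (Tail, strain ICR) with Mus musculus as the target, in the tail flick test, with a stated time of 120 min, at a dose of 25 umol/kg by the oral route (on this read-out lower numbers stand for a weaker effect and higher numbers for a stronger effect at the one dose given), compound 1 holds the highest of the three numbers, yet its gaps to compound 2 and to compound 3 both lie within the usual scatter, so the three compounds cannot really be told apart on this read-out.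

Compound 4, `C[C@H](NC(=O)CN(c1nc(Cl)nc2[nH]cnc12)C1CC1)C(=O)O`, differs from compound 1 in one place: hydrogen in place of carbamoyl on a saturated chain carbon, two bonds along the chain from an amide-type nitrogen and a carbonyl carbon.

Among the measured compounds shown here, only one step among the measured compounds is available, a number 3.1 percentage points lower from compound 2 to compound 3 (within the scatter), and it concerns a different change on a different core; no measured step removes a carbamoyl. That single step stayed within the scatter, and nothing shown suggests that removing the carbamoyl should act differently. The expectation is therefore that a number 2 percentage points lower from compound 1 to compound 4 (within the scatter) will not exceed the scatter. On that basis compound 4 is estimated at 15%, with a likely range from 5% to 27%.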

Compound 4, a percentage reported as activity, at one dose (the size of the read-out at that dose, not a potency): 28.4%
Compound 4: middle estimate off by 13.4 percentage points, on the low side, outside the stated range (above it).
By their numbers in this assay, from the lowest: compounds 3, 2 and 1 (each within the scatter of the next); then compound 4.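

Replacing the carbamoyl with hydrogen on this saturated chain carbon is the only single change among these compounds that moves the result beyond the scatter: in this assay it gives a number 11.4 percentage points higher from compound 1 to compound 4 (beyond the scatter). This shows that the group at this position can alter the effect at the one dose given, and that the carbamoyl is not required for activity on the core of compound 1. No evidence is available to explain the rise.

From the compounds shown here alone, with a single exchange on one core, it remains open whether the rise belongs to methyl alone or extends to other side chains. Placing carboxymethyl, aminomethyl or a longer chain such as propyl on this carbon would test how much this position tolerates.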